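Ring-nitrogen substituent and whole-animal inhibition in the series

This account rests on a few compounds, and the source may have more. Where it says the series, first, only, none or still open, it means among the compounds named here.

Measured so far, in a functional assay on the whole organism with Rattus norvegicus as the target, at a dose of 40 mg/kg by the intraperitoneal route; a lower number here means less inhibition, a higher number more inhibition at the dose given (going by the name of the read-out):
compound 1, `Nc1cnc2c(OCc3ccccc3)cccn12`, gives 32%
compound 2, `COC(=O)Nc1c(C)nc2c(OCc3ccccc3)cccn12`, gives 0%
compound 3, `Cc1nc2c(OCc3ccccc3)cccn2c1NC(=O)OCc1ccccc1`, gives 8%

Compound 2 stands lowest of the three numbers. Going by the values given here, its nearest neighbour is compound 3, which lies within the scatter of it; the one step measured, a number 8 percentage points higher from compound 2 to compound 3 (within the scatter), is therefore not a real change. Compound 1, with a free amino group on the shared core and no methyl, sits beyond the scatter above compound 2.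

The next compound, compound 4, `CCCNc1c(C)nc2c(OCc3ccccc3)cccn12`, differs from compound 2 in one place: propyl in place of methoxycarbonyl on a nitrogen on an aromatic ring. Among the compounds with values here, no measured step bears directly on this change. Within the data shown here, the one step available, from compound 2 to compound 3, alters the ester end of the same group and leaves the carbonyl in place, and it moved nothing beyond the scatter. Among the measured compounds shown here, the only number that differs clearly from compound 2 belongs to compound 1, where the ring nitrogen carries hydrogen alone rather than a carbonyl group. Removing the carbonyl in compound 4 may therefore move the read-out upward, but the size is not fixed by the data.

Compound 4 is estimated at 15%, in the range 0% to 40%; the expected step is a number 15 percentage points higher from compound 2 to compound 4 (beyond the scatter).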

Compound 4, a percentage reported as inhibition, in the whole organism at one dose (the size of the read-out at that dose, not a potency): 99%
Compound 4: the middle estimate sits 84 percentage points below what was measured; measured number above the stated range.
By their numbers in this assay, from the lowest: compounds 2 and 3 (each within the scatter of the next); then compound 1; then compound 4.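

Going by these compounds alone, at the nitrogen on an aromatic ring, the choice of group has a large effect on the read-out in this assay and the step of a number 99 percentage points higher from compound 2 to compound 4 (beyond the scatter) is the first change at this place that lies beyond the scatter. The earlier step of a number 8 percentage points higher from compound 2 to compound 3 (within the scatter) altered only the ester end and kept the carbonyl, so it gave no sign that this place could respond so strongly. Nothing available explains the size of the new step, and the exchange removes the carbonyl and both oxygens while adding a plain propyl chain, so the compounds cannot say which part of it matters.

A butanoyl group on the same nitrogen would keep the carbonyl with a chain of similar reach and so help separate these two parts of the change, while ethyl or butyl would show whether the chain length matters. As far as these compounds go, with compound 4 at 99% in a read-out taken at one dose, it also remains open how far the effect would persist at lower doses, and so how such chains would rank against propyl.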